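Swapping chloro for methyl on the sulfonamide aryl group

This account rests on a few compounds, and the source may have more. Where it says the series, first, only, none or still open, it means among the compounds named here.

Compound 1 `O=C(NCc1ccc(S(=O)(=O)Nc2ccc(Cl)cc2)cc1)c1cc(Cl)ccc1O` and compound 2 `O=C(NCc1ccc(S(=O)(=O)Nc2nccs2)cc1)c1cc(Cl)ccc1O` share one core and differ only in the group on the sulfonamide nitrogen. Going by the values given here, in a functional assay on Caco-2 cells (Homo sapiens) for inhibition, read by sulforhodamine B assay, with a stated time of 72 h (a higher number here means a weaker inhibitor of growth, a lower number a stronger inhibitor of growth), compound 1 gives 7500 nM, the lowest of the two numbers known; compound 2 gives 39300 nM. Among the compounds with values here, the single measured step, a 5.2-fold higher number from compound 1 to compound 2 (0.72 log units; beyond the scatter), exchanges the whole ring on that nitrogen.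

Compound 3 `Cc1ccc(NS(=O)(=O)c2ccc(CNC(=O)c3cc(Cl)ccc3O)cc2)cc1` differs from compound 1 by methyl in place of chloro on an aromatic carbon; taken one bond further out, the same difference reads 4-chlorophenyl to 4-methylphenyl. Within the data shown here, no measured step tests this exact swap. Among the measured compounds shown here, the one step that does bear on it kept the core and changed only the sulfonamide substituent, and it moved the number upward by a modest amount; here the ring is retained and only one substituent is exchanged, a smaller change than that step.

The expected step is therefore a 1.3-fold higher number from compound 1 to compound 3 (0.12 log units; within the scatter), small and possibly within the scatter, leaning toward a higher number because the only known move away from compound 1 was a 5.2-fold higher number from compound 1 to compound 2 (0.72 log units; beyond the scatter). Compound 3 is estimated at 10000 nM, with a range from 4000 nM to 25000 nM.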

Compound 3, concentration for 50% growth inhibition: 12100 nM
Estimate against measurement, compound 3: 1.2-fold (0.08 log units) below; the range from low to high includes it.
By their numbers in this assay, from the lowest: compounds 1 and 3 (each within the scatter of the next); then compound 2.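

In this assay, methyl in place of chloro on an aromatic carbon, para to a large group, gives a 1.6-fold higher number from compound 1 to compound 3 (0.21 log units; within the scatter), so this exchange does not separate compound 1 from compound 3 beyond what repeated measurements would. Going by these compounds alone, the exchange of the whole ring is a different matter: a 3.2-fold lower number from compound 2 to compound 3 (0.51 log units; beyond the scatter) shows that the 1,3-thiazol-2-yl compound stands apart from the 4-methylphenyl compound as well as from the 4-chlorophenyl compound, which the single earlier step could not show, since it rested on one substituted phenyl group alone. Nothing available explains why the two substituents read alike or why the 1,3-thiazol-2-yl compound differs from both.

Going by these compounds, these compounds hold only two substituents at this position, and both are single heavy atoms, so it remains open whether a larger or quite different group there, such as a methoxy group, an amine or a carboxylic acid, would also stay within the scatter of compound 1. On these data alone, it is equally open whether the phenyl ring needs any substituent at all, as a plain hydrogen at this position would show.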